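This account rests on a few compounds, and the source may have more. Where it says the series, first, only, none or still open, it means among the compounds named here.

Measured so far in a functional assay on HO8910 cells (Homo sapiens) for cytotoxicity, read by CCK-8 assay, with a stated time of 24 h; a lower number here means a stronger inhibitor, a higher number a weaker inhibitor:
Compound 1 `C/C(=C\c1cc(-c2ccc(C)nc2)co1)C(N)=O`: > 50000 nM, a limit of the assay.
Compound 2 `C/C(=C\c1cc(-c2ccc(F)nc2)co1)C(N)=O`: 30000 nM.
Compound 3 `C/C(=C\c1cc(-c2ccc(C)cc2)cs1)C(N)=O`: > 50000 nM, a limit of the assay.

Compound 1 and compound 3 carry different cores; how the two cores differ is not broken down here. Within the core of compound 1, the change to compound 2 is fluoro in place of methyl on an aromatic carbon and it gives an at least 1.6-fold lower number from compound 1 to compound 2 (0.22 log units; that floor lies within the scatter). That the size of the step is known only as a floor rests on (the limit of > 50000 nM in this assay, at which 2 of the 3 values shown sit).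

Compound 4 `C/C(=C\c1cc(-c2ccc(F)cc2)cs1)C(N)=O` is not yet measured. It stands to compound 3 as fluoro in place of methyl on an aromatic carbon, the same kind of change as before, though not the same: here the ring is of carbon only, whereas from compound 1 to compound 2 the ring holds one nitrogen and the entering fluoro sits next to the ring nitrogen. Among the compounds with values here, the step expected here, an at least 1.2-fold lower number from compound 3 to compound 4 (0.09 log units; that floor lies within the scatter), is set beside the measured one, an at least 1.6-fold lower number from compound 1 to compound 2 (0.22 log units; that floor lies within the scatter), since that is the only guide available. Compound 3 sits at a limit of the assay, > 50000 nM, so the starting point is itself uncertain. Compound 4 is therefore expected near 40000 nM, between 15000 nM and 100000 nM, with a fair chance that this assay again reports only a limit.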

Compound 4, half-maximal inhibitory concentration: > 50000 nM
Compound 4: no number, only a limit (the forecaster's own chance of this, stated with the estimate: 50%); middle value at least 1.2-fold (0.09 log units) away from the limit.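

Compound 3 and compound 4 both give only a limit in this assay, so no step between them can be read: the limit of > 50000 nM in this assay, at which 3 of the 4 values shown sit.

Going by these compounds, whether fluoro in place of methyl on an aromatic carbon changes the number at all within the core of compound 3 stays open.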